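Piperazine-linked pyrazoles: swapping the aryl group on ring nitrogen

A few compounds are considered here, and "the series" means these few. Any claim that something is new, unique, unknown or untested is made for them only; others in the source may bear on it.

Compound 1, `CN1CCN(CCCNCc2cn(-c3ccc(C(F)(F)F)cc3)nc2-c2ccc(OC(F)(F)F)cc2)CC1`, gives 2300 nM in an ADME assay on Huh-7 cells (Homo sapiens) for cytotoxicity; a lower number here means that less compound is tolerated, a higher number that more compound is tolerated. Compound 2, `Cc1ccccc1CNc1nn(-c2ccc(F)cc2F)cc1CNCCN1CCN(C)CC1`, gives only a limit in this assay, > 20000 nM. Compound 3, `CN1CCN(CCNCc2cn(-c3ccc(F)cc3F)nc2-c2ccc(OC(F)(F)F)cc2)CC1`, gives 18000 nM in this assay.

Among the two plain numbers, compound 3 stands highest; compound 1 sits well lower, and the two compounds differ in more than one place, so the gap is noted only as what the two values show. For the measured compounds named here, the single measured step, an at least 1.1-fold lower number from compound 2 to compound 3 (0.04 log units; that floor lies within the scatter), rests on a limit and cannot be sized beyond its floor; it concerns a change on an aromatic carbon and does not bear on the change now followed.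

Compound 4, `CN1CCN(CCNCc2cn(-c3ccc(C(F)(F)F)cc3)nc2-c2ccc(OC(F)(F)F)cc2)CC1`, differs from compound 3 by 4-(trifluoromethyl)phenyl in place of 2,4-difluorophenyl on an aromatic nitrogen. Compound 1 carries the same 4-(trifluoromethyl)phenyl group and gives 2300 nM, so a lower number than compound 3 is expected for compound 4, though the chain differs between compound 1 and compound 4 and the size is uncertain. The expected step is a 3.6-fold lower number from compound 3 to compound 4 (0.56 log units; beyond the scatter). Compound 4 is estimated at 5000 nM, between 1800 nM and 14000 nM.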

Compound 4, half-maximal cytotoxic concentration: 3000 nM
Compound 4: middle estimate off by 1.7-fold (0.22 log units), on the high side, within the range that was stated.
By their numbers in this assay, from the lowest: compounds 1 and 4 (each within the scatter of the next); then compound 3. At a limit, above all of these: compound 2.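

In this assay there is now a 6.0-fold lower number from compound 3 to compound 4 (0.78 log units; beyond the scatter) on putting 4-(trifluoromethyl)phenyl in place of 2,4-difluorophenyl on the aromatic nitrogen with the rest of the molecule unchanged; compound 1 and compound 3, which differ in more than one place, could not give that size. For the compounds shown here, the chain change, 4-methylpiperazin-1-yl in place of (4-methylpiperazin-1-yl)methyl, gives a 1.3-fold higher number from compound 1 to compound 4 (0.12 log units; within the scatter) with 4-(trifluoromethyl)phenyl held on the ring nitrogen, so the aryl change is the only one of the two steps that lies beyond the scatter. Nothing at hand accounts for why this aryl swap lowers the number.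

Still open, from the compounds shown here alone, is whether a plain phenyl, a 4-fluorophenyl or a 4-chlorophenyl on that nitrogen would sit with compound 3 or with compound 4. Also open, going by these compounds, is whether the longer chain would leave the number unchanged with 2,4-difluorophenyl on that nitrogen.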